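A Second Methyl on the Amide Aryl Ring

The compounds below may be only part of what the source reports. "The series", "measured", "known", "first", "only" and "open" are said of these compounds alone.

Compound 1 `O=C(Nc1cccc(-c2oc3cc(-c4ccc(F)cc4)ccc3c(=O)c2O)c1)c1ccc(Br)cc1` gives 9740 nM in a functional assay on HeLa cells (Homo sapiens) for antiproliferative activity, read by CCK-8 assay, with a stated time of 72 h; on this read-out higher numbers stand for weaker inhibition and lower numbers for stronger inhibition. Compound 2 `COc1cccc(C(=O)Nc2cccc(-c3oc4cc(-c5ccc(F)cc5)ccc4c(=O)c3O)c2)c1` gives 5650 nM in this assay. Compound 3 `Cc1cccc(C(=O)Nc2cccc(-c3oc4cc(-c5ccc(F)cc5)ccc4c(=O)c3O)c2)c1` gives 6650 nM in this assay.

Compound 3 holds the second highest of the three numbers. Its step from compound 2 is a 1.2-fold higher number from compound 2 to compound 3 (0.07 log units; within the scatter), and its step from compound 1 is a 1.5-fold lower number from compound 1 to compound 3 (0.17 log units; within the scatter), so all three values sit within the usual scatter of one another and no ordering among them can be claimed.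

Compound 4 `Cc1cc(C)cc(C(=O)Nc2cccc(-c3oc4cc(-c5ccc(F)cc5)ccc4c(=O)c3O)c2)c1` differs from compound 3 by one change: methyl in place of hydrogen on an aromatic carbon. The measured steps that bear on this are the three exchanges of the group on the carbonyl carbon, a 1.7-fold lower number from compound 1 to compound 2 (0.24 log units; within the scatter), a 1.5-fold lower number from compound 1 to compound 3 (0.17 log units; within the scatter) and a 1.2-fold higher number from compound 2 to compound 3 (0.07 log units; within the scatter); none of them moved this assay beyond the scatter. A further methyl on the same ring is a smaller change than any of these, so no step beyond the scatter is expected in this assay. The expected step is a 1.1-fold lower number from compound 3 to compound 4 (0.04 log units; within the scatter). Compound 4 is therefore estimated at 6000 nM, within a range from 3000 nM to 12000 nM.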

Compound 4, half-maximal inhibitory concentration: 5540 nM
Compound 4: the middle estimate sits 1.1-fold (0.03 log units) above what was measured; the range from low to high includes it.
By their numbers in this assay, from the lowest: compounds 4, 2, 3 and 1 (each within the scatter of the next).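

Adding a second methyl to turn the 3-methylphenyl into the 3,5-dimethylphenyl leaves this assay within the scatter, with a 1.2-fold lower number from compound 3 to compound 4 (0.08 log units; within the scatter) as the step. The 3,5-dimethylphenyl group also sits within the scatter of the other two groups on the carbonyl carbon, with a 1.0-fold lower number from compound 2 to compound 4 (0.01 log units; within the scatter) and a 1.8-fold lower number from compound 1 to compound 4 (0.25 log units; within the scatter) as its steps, so the four compounds cannot be ordered and this ring has accepted a second methyl without a readable shift. Nothing available here accounts for this flat result.

The compounds shown leave open whether an amine or a carboxylic acid on this ring, or a longer chain in place of the methyl, would move the number beyond the scatter. From the compounds shown here alone, whether the same flat picture holds in any other cell line also stays open.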